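The source may hold more compounds than are shown below. What is called first, only, known or untested is meant among the compounds shown, and "the series" means these compounds.

The compounds considered here share one core and differ only in the chain carried on the amide nitrogen. Compound 1 `CCn1c(C(=O)NCCO)ccc1C(CC)(CC)c1ccc(OCC(O)C(C)(C)C)c(C)c1` bears a 2-hydroxyethyl chain there; in a functional assay on MCF7 cells (Homo sapiens) for cytotoxicity, read by MTT assay, with a stated time of 48 h (a lower number here means a stronger inhibitor, a higher number a weaker inhibitor), compound 1 gives 1810 nM. Compound 2 `CCn1c(C(=O)N[C@@H](C)CO)ccc1C(CC)(CC)c1ccc(OCC(O)C(C)(C)C)c(C)c1` gives 307 nM, and compound 3 `CCn1c(C(=O)N[C@H](CO)CCO)ccc1C(CC)(CC)c1ccc(OCC(O)C(C)(C)C)c(C)c1` gives 300 nM. Compound 3 thus shows the lowest of the three numbers, but its gap to compound 2, a 1.0-fold lower number from compound 2 to compound 3 (0.01 log units; within the scatter), lies within the scatter, so the two cannot be ranked against each other. The step of a 6.0-fold lower number from compound 1 to compound 3 (0.78 log units; beyond the scatter) and the parallel step a 5.9-fold lower number from compound 1 to compound 2 (0.77 log units; beyond the scatter) are of much the same size, so both branched chains move the number by a similar amount.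

Compound 4 `CCn1c(C(=O)N[C@@H](C)C(=O)O)ccc1C(CC)(CC)c1ccc(OCC(O)C(C)(C)C)c(C)c1` is the next step: 1-carboxyethyl in place of 3-hydroxy-1-(hydroxymethyl)propyl on an amide-type nitrogen. For the measured compounds named here, compound 4 keeps the methyl on the chain carbon bound to the amide-type nitrogen that compound 2 carries, but no measured step exchanges a hydroxymethyl for a carboxyl, so the direction of this change is open. The expected step in this assay is therefore a 1.7-fold higher number from compound 3 to compound 4 (0.22 log units; within the scatter), a change that need not clear the scatter. The estimate for compound 4 is 500 nM, with a range from 150 nM to 1800 nM.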

Compound 4, half-maximal inhibitory concentration: 180 nM
For compound 4 the middle estimate is 2.8-fold (0.44 log units) above the measured one, and the stated range covers the measured number.
By their numbers in this assay, from the lowest: compounds 4, 3 and 2 (each within the scatter of the next); then compound 1.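

In this assay the step of a 1.7-fold lower number from compound 2 to compound 4 (0.23 log units; within the scatter) exchanges hydroxymethyl for carboxy on the same chain carbon, and the step of a 1.7-fold lower number from compound 3 to compound 4 (0.22 log units; within the scatter) likewise does not separate its pair, so compound 4 cannot be ranked against compound 2 or compound 3. Until now, every chain on the amide-type nitrogen carried only hydroxyl groups, whereas compound 4 shows that a chain ending in carboxy can give a number in the same range as the two branched hydroxyl chains. The step of a 10-fold lower number from compound 1 to compound 4 (1.00 log units; beyond the scatter) also places compound 4 clearly apart from compound 1, so all three chains with a substituent on the carbon bound to the amide-type nitrogen stand apart from the unbranched 2-hydroxyethyl chain, and none of the four compounds goes against this.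

Nothing available explains why these three chains group together or why compound 1 stands apart. On these data alone, an unbranched chain ending in a carboxylic acid would help separate the part played by the methyl on the chain from that of the end group, and whether an amine or a methyl ester in place of the carboxy would stay in this range also remains open.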